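A few compounds are considered here, and "the series" means these few. Any claim that something is new, unique, unknown or untested is made for them only; others in the source may bear on it.

Measured in an assay on CHO-K1 cells for displacement of a labelled ligand from prostaglandin E2 receptor EP1 subtype (Homo sapiens); a higher number here means a weaker inhibitor, a lower number a stronger inhibitor:
compound 1 `Cc1cc(C(=O)O)nn1Cc1cc(Br)ccc1OCc1ccccc1` gives 6.46 nM
compound 2 `Cc1cc(C(=O)O)nn1Cc1cc(Br)ccc1OCc1cccc(Br)c1` gives 17.8 nM
compound 3 `Cc1cccc(COc2ccc(Br)cc2Cn2nc(C(=O)O)cc2C)c1` gives 126 nM

Compound 3 stands highest of the three in this assay: a 7.1-fold higher number from compound 2 to compound 3 (0.85 log units; beyond the scatter), and a 20-fold higher number from compound 1 to compound 3 (1.29 log units; beyond the scatter). Compound 4 `Cc1cc(C(=O)O)nn1Cc1cc(Br)ccc1OCc1cccc(C(F)(F)F)c1` differs from compound 3 by trifluoromethyl in place of methyl on an aromatic carbon. Among the compounds with values here, the steps that bear on this are the two additions to the unsubstituted ring of compound 1, a 2.8-fold higher number from compound 1 to compound 2 (0.44 log units; beyond the scatter) and a 20-fold higher number from compound 1 to compound 3 (1.29 log units; beyond the scatter), and the exchange between them, a 7.1-fold higher number from compound 2 to compound 3 (0.85 log units; beyond the scatter); so far the only group other than methyl tried there gave a lower number than methyl. Trifluoromethyl itself is untested, so the expectation is a modest step down in this assay, a 3.2-fold lower number from compound 3 to compound 4 (0.50 log units; beyond the scatter), with wide uncertainty. Compound 4 is therefore estimated at 40 nM, range 12 nM to 130 nM.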

Compound 4, half-maximal inhibitory concentration: 309 nM
Compound 4: the middle estimate sits 7.7-fold (0.89 log units) below what was measured; the whole stated range lies below it.
By their numbers in this assay, from the lowest: compound 1; then compound 2; then compound 3; then compound 4.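

In this assay, trifluoromethyl on this aromatic carbon gives the highest number in the series, with steps of (a 2.5-fold higher number from compound 3 to compound 4 (0.39 log units; beyond the scatter)), (a 17-fold higher number from compound 2 to compound 4 (1.24 log units; beyond the scatter)) and (a 48-fold higher number from compound 1 to compound 4 (1.68 log units; beyond the scatter)). Methyl therefore no longer marks the upper end, and none of the three groups tried at this position gives a lower number than hydrogen. No measurement shown accounts for this order.

From the compounds shown here alone, whether fluoro, chloro, methoxy or an amine at this position would come closer to hydrogen remains open. So does whether the same order would hold elsewhere on this ring.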